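The compounds below may be only part of what the source reports. "The series", "measured", "known", "first", "only" and "open" are said of these compounds alone.

Measured so far:
- compound 1, `CCN(CC)C(=O)[C@@H]1CCCN(S(=O)(=O)c2ccc(S(=O)(=O)N(CC)CC)cc2)C1`, giving 10500 nM in a functional assay on BXPC-3 cells (Homo sapiens) for inhibition, read by MTT assay, with a stated time of 7 days; on this read-out higher numbers stand for weaker inhibition and lower numbers for stronger inhibition
- compound 2, `CCN(CC)S(=O)(=O)c1ccc(S(=O)(=O)N2CCC[C@@H](C(=O)NC3COC3)C2)cc1`, giving 13800 nM in this assay
- compound 3, `CCN(CC)S(=O)(=O)c1ccc(S(=O)(=O)N2CCC[C@@H](C(=O)NC)C2)cc1`, giving 13800 nM in this assay

Compound 3 stands level with compound 2 at the digits shown, the two together the highest numbers of the three; compound 1 is the furthest away, yet only by a 1.3-fold higher number from compound 1 to compound 3 (0.12 log units; within the scatter). All three share one core and differ only in the group on the amide nitrogen.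

Compound 4, `CCN(CC)S(=O)(=O)c1ccc(S(=O)(=O)N2CCC[C@@H](C(=O)NC3CN(C(=O)NC(C)(C)C)C3)C2)cc1`, continues this series: 1-((tert-butyl)carbamoyl)azetidin-3-yl in place of methyl on an amide-type nitrogen. For the measured compounds named here, the steps that bear on it are a 1.3-fold higher number from compound 1 to compound 2 (0.12 log units; within the scatter) and no change at the digits printed from compound 2 to compound 3 (within the scatter), both changes at the same amide nitrogen and both within the scatter. On that basis no step beyond the scatter is expected in this assay, that is a 1.0-fold higher number from compound 3 to compound 4 (0.01 log units; within the scatter). Compound 4 is therefore estimated at 14000 nM, with a range from 6000 nM to 35000 nM.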

Compound 4, half-maximal inhibitory concentration: 10100 nM
The estimate for compound 4 lay 1.4-fold (0.14 log units) above the measured number; low and high end bracket the measured number.
By their numbers in this assay, from the lowest: compounds 4, 1, 2 and 3 (each within the scatter of the next).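

In this assay, a 1.4-fold lower number from compound 3 to compound 4 (0.14 log units; within the scatter) and a 1.4-fold lower number from compound 2 to compound 4 (0.14 log units; within the scatter) and a 1.0-fold lower number from compound 1 to compound 4 (0.02 log units; within the scatter) show that even 1-((tert-butyl)carbamoyl)azetidin-3-yl, with its four-membered ring and 11 heavy atoms, gives no step beyond the scatter. Across these four compounds, groups from methyl up to this one on the amide nitrogen leave the number within the scatter. Nothing available explains this flat result.

As far as these compounds go, whether an amine or a carboxylic acid on this amide nitrogen would give a step beyond the scatter stays open. So do changes elsewhere on the shared core.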